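The source may hold more compounds than are shown below. What is called first, only, known or untested is meant among the compounds shown, and "the series" means these compounds.

Measured compounds:
- compound 1 `N#Cc1cnc(NCc2cnccc2C(F)(F)F)cc1NC[C@H]1C[C@H](O)C1` — 700 nM
- compound 2 `N#Cc1cnc(NCc2ccccc2C(F)(F)F)cc1N[C@H]1C[C@@H](C(N)=O)C1` — 150 nM
- compound 3 `N#Cc1cnc(NCc2ccccc2C(F)(F)F)cc1N[C@H]1CC[C@@H](C(N)=O)CC1` — 20 nM

In an assay on isolated protein for inhibition of protein kinase C theta type (Homo sapiens), read by TR-FRET, with a stated time of 2 h (on this read-out lower numbers stand for stronger inhibition and higher numbers for weaker inhibition), compound 1 gives the highest number of the three measured compounds; compound 2 stands nearer to it and compound 3 furthest from it, both steps beyond the scatter.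

The unmeasured compound 4 `CC1(C)C[C@@H](Nc2cc(NCc3cnccc3C(F)(F)F)ncc2C#N)CC[C@H]1O` keeps the core of compound 1 and alters the group on the ring nitrogen: 4-hydroxy-3,3-dimethylcyclohexyl in place of (3-hydroxycyclobutyl)methyl on a nitrogen on an aromatic ring.

Going by the values given here, the one measured step that bears on this change is a ring enlargement on the same nitrogen, a 7.5-fold lower number from compound 2 to compound 3 (0.88 log units; beyond the scatter), where a four-membered ring gives way to a six-membered one. Compound 4 also moves from a four-membered to a six-membered ring, though here the methylene link leaves and two methyl groups enter with the hydroxyl, so the match is partial. The expectation for compound 4 is therefore a lower number, of the order of that step or somewhat smaller, a 5.8-fold lower number from compound 1 to compound 4 (0.77 log units; beyond the scatter). Compound 4 is estimated at 120 nM, with a range of 30 nM to 450 nM.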

Compound 4, half-maximal inhibitory concentration: 120 nM
Compound 4: the middle estimate sits on the measured number at the digits printed, within the range that was stated.
By their numbers in this assay, from the lowest: compound 3; then compounds 4 and 2 (each within the scatter of the next); then compound 1.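

In this assay, the position on the nitrogen on an aromatic ring tolerates a much larger group on the core of compound 1: 4-hydroxy-3,3-dimethylcyclohexyl in place of (3-hydroxycyclobutyl)methyl gives a 5.8-fold lower number from compound 1 to compound 4 (0.77 log units; beyond the scatter). The earlier ring-size step, a 7.5-fold lower number from compound 2 to compound 3 (0.88 log units; beyond the scatter), came from carbamoyl-bearing rings on a different core, so a lower number on moving to a six-membered ring now also appears with a hydroxyl-bearing ring on the core of compound 1. No measurement available here explains this result.

The step combines the change in ring size, the loss of the methylene link and the entry of two methyl groups, so their shares remain unresolved. On these data alone, a plain 4-hydroxycyclohexyl would separate these contributions, and the effect of a primary amine or carboxylic acid in place of the hydroxyl remains open.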